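Lipoic amide coumarins: a bromine added to a phenyl

The compounds below may be only part of what the source reports. "The series", "measured", "known", "first", "only" and "open" are said of these compounds alone.

Measured compounds:
- compound 1, `COc1ccc(-c2cc3ccc(OCCCn4cc(CNC(=O)CCCCC5CCSS5)nn4)cc3oc2=O)cc1`: 42%
- compound 2, `O=C(CCCCC1CCSS1)NCc1cn(CCCCOc2ccc3cc(-c4ccccc4)c(=O)oc3c2)nn1`: 38.6%

Both measured compounds were run in a functional assay on PC-12 cells (Rattus norvegicus) for cytotoxicity, read by MTT assay, with stated times of 3 h and 2 h, tested at 0.1 uM; on this read-out lower numbers stand for a weaker effect and higher numbers for a stronger effect at the one concentration tested. Compound 1 gives 42% and compound 2 gives 38.6%. Of the two numbers compound 2 is the lower, but the gap to compound 1 is within the scatter of repeated measurements, so the two cannot be told apart on this evidence.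

Compound 3, `O=C(CCCCC1CCSS1)NCc1cn(CCCCOc2ccc3cc(-c4ccc(Br)cc4)c(=O)oc3c2)nn1`, is the next compound. It differs from compound 2 in one place only: bromo in place of hydrogen on an aromatic carbon. The new atom sits on an aromatic carbon of a six-membered aromatic ring of carbon only, para to a large group, so the phenyl becomes a 4-bromophenyl while the rest of the molecule is kept.

Among the compounds with values here, no pair of measured compounds shows what such a change does here, so the expectation rests on the two values alone. The step from compound 2 to compound 3 is expected to be small, a number 1.4 percentage points higher from compound 2 to compound 3 (within the scatter), and not beyond the scatter in either direction. Compound 3 is therefore estimated at 40%, within a range of 26% to 54%.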

Compound 3, a percentage reported as activity, at one concentration (the size of the read-out at that concentration, not a potency): 34.2%
Compound 3: the middle estimate sits 5.8 percentage points above what was measured; low and high end bracket the measured number.
By their numbers in this assay, from the lowest: compounds 3, 2 and 1 (each within the scatter of the next).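

Within the data shown here, this is the first reading of a change at a single place. In this assay, replacing the hydrogen with bromo on the six-membered aromatic ring, para to a large group, gives a number 4.4 percentage points lower from compound 2 to compound 3 (within the scatter), so turning the phenyl into a 4-bromophenyl does not separate the two compounds on this read-out, and at this position a single added bromine, with the rest of the molecule kept, leaves no effect that can be distinguished from the ordinary spread of repeated measurements. Nothing available here bears on why the result came out this way, and one step with one substituent supports no general rule for this position.

As far as these compounds go, what an amine, a carboxylic acid or a longer chain would do at the same place on the phenyl remains open, and so does whether a group of that kind would move the number beyond the scatter. From the compounds shown here alone, with each compound read at only one concentration, it also remains open whether compound 2 and compound 3 would stay indistinguishable at other concentrations.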